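The compounds below may be only part of what the source reports. "The series", "measured", "known", "first", "only" and "open" are said of these compounds alone.

In a functional assay on LNCaP cells (Homo sapiens) for antiproliferative activity, read by propidium iodide staining, with a stated time of 96 h (a lower number here means a stronger inhibitor, a higher number a weaker inhibitor), three compounds built on a shared core have been measured. Compound 1 `CC(O)(CS(=O)(=O)c1cccc(S(F)(F)(F)(F)F)c1)C(=O)Nc1cccc(S(F)(F)(F)(F)F)c1` gives 11700 nM, compound 2 `CC(O)(CS(=O)(=O)c1cccc(C(F)(F)F)c1)C(=O)Nc1cccc(S(F)(F)(F)(F)F)c1` gives 21800 nM and compound 3 `CC(O)(CS(=O)(=O)c1ccc(OC(F)(F)F)cc1)C(=O)Nc1cccc(S(F)(F)(F)(F)F)c1` gives 10700 nM. Compound 3 thus stands level with compound 1, within the scatter, and apart from compound 2.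

Compound 4 `CC(O)(CS(=O)(=O)c1cccc(OC(F)(F)F)c1)C(=O)Nc1cccc(S(F)(F)(F)(F)F)c1` has the same atoms as compound 3, joined differently: 3-(trifluoromethoxy)phenyl in place of 4-(trifluoromethoxy)phenyl on a sulfonyl sulfur. In words, it carries 3-(trifluoromethoxy)phenyl in place of 4-(trifluoromethoxy)phenyl on a sulfonyl sulfur. For the measured compounds named here, no measured step moves this group alone, so the evidence is indirect. Going by the values given here, two steps bear on it: a 2.0-fold lower number from compound 2 to compound 3 (0.31 log units; beyond the scatter), which swapped the group and its place together and is only modest, and a 1.9-fold higher number from compound 1 to compound 2 (0.27 log units; within the scatter), which involves a different group. With steps this small, no change beyond the scatter is expected in this assay, at most a slight drift toward a higher number. The expected step is a 1.3-fold higher number from compound 3 to compound 4 (0.12 log units; within the scatter). For compound 4 the estimated value is 14000 nM, with an expected range from 7500 nM to 26000 nM.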

Compound 4, half-maximal inhibitory concentration: 15100 nM
Estimate against measurement, compound 4: 1.1-fold (0.03 log units) below, within the range that was stated.
By their numbers in this assay, from the lowest: compounds 3, 1, 4 and 2 (each within the scatter of the next, the first and the last beyond it).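

In this assay, 3-(trifluoromethoxy)phenyl in place of 4-(trifluoromethoxy)phenyl on the sulfonyl sulfur gives a 1.4-fold higher number from compound 3 to compound 4 (0.15 log units; within the scatter), and trifluoromethoxy in place of trifluoromethyl on the aromatic carbon gives a 1.4-fold lower number from compound 2 to compound 4 (0.16 log units; within the scatter), so the earlier combined change, a 2.0-fold lower number from compound 2 to compound 3 (0.31 log units; beyond the scatter), divides into two single changes, neither beyond the scatter on its own. Trifluoromethoxy in place of pentafluorosulfanyl on that carbon gives a 1.3-fold higher number from compound 1 to compound 4 (0.11 log units; within the scatter), which leaves the three groups compared there without a separation beyond the scatter. No measurement at hand explains these small differences.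

Still open, going by these compounds, is whether an amine or a carboxylic acid on this aromatic carbon would shift the number beyond the scatter. Also open, on these data alone, is the effect of a change on the ring at the amide nitrogen, such as a nitrile in place of pentafluorosulfanyl, since that ring is the same in all four compounds.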